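A few compounds are considered here, and "the series" means these few. Any claim that something is new, unique, unknown or untested is made for them only; others in the source may bear on it.

Measured so far in an ADME assay on the whole organism for inhibition, with Oryza sativa as the target, with a stated time of 4 days; a lower number here means a stronger inhibitor, a higher number a weaker inhibitor:
- compound 1 `CC(C)N(c1nc(Cl)nc(N[C@@H](C)c2ccccc2)n1)C(C)C` gives 372 nM
- compound 2 `CC[C@H](C)Nc1nc(Cl)nc(N[C@@H](C)c2ccccc2)n1` gives 6920 nM
- compound 3 `CC[C@@H](C)Nc1nc(Cl)nc(N[C@@H](C)c2ccccc2)n1` gives 9770 nM

Compound 1 stands lowest of the three. The step to compound 2 is a 19-fold higher number from compound 1 to compound 2 (1.27 log units; beyond the scatter) and the step to compound 3 is a 26-fold higher number from compound 1 to compound 3 (1.42 log units; beyond the scatter), both large. Between compound 2 and compound 3 the step is a 1.4-fold higher number from compound 2 to compound 3 (0.15 log units; within the scatter), which is the expected outcome given (the fact that compounds 2 and 3 differ only in the configuration as drawn).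

Compound 4 `CCN(CC)c1nc(Cl)nc(N[C@@H](C)c2ccccc2)n1` has not yet been measured. It differs from compound 1 in one place: diethylamino in place of diisopropylamino on an aromatic carbon. The two measured steps that bear on this place both swap the diisopropylamino for a (sec-butyl)amino and both raise the number a great deal. Diethylamino is a smaller tertiary amine than diisopropylamino, so a rise in this assay is expected, probably less steep than in those two steps.

Compound 4 is therefore expected at 1500 nM, within 500 nM to 5000 nM. The step this estimate implies is a 4.0-fold higher number from compound 1 to compound 4 (0.61 log units; beyond the scatter), expected to lie beyond the scatter.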

Compound 4, half-maximal inhibitory concentration: 380 nM
Compound 4: middle estimate off by 3.9-fold (0.60 log units), on the high side, and the stated range ends above it.
By their numbers in this assay, from the lowest: compounds 1 and 4 (each within the scatter of the next); then compounds 2 and 3 (each within the scatter of the next).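

At this position, the exchange of diisopropylamino for diethylamino, with fewer heavy atoms, leaves the read-out in this assay unresolved (a 1.0-fold higher number from compound 1 to compound 4 (0.01 log units; within the scatter)), so the low number of compound 1 does not depend on diisopropylamino alone. Against either drawn configuration of (sec-butyl)amino, diethylamino gives a large separation (a 26-fold lower number from compound 3 to compound 4 (1.41 log units; beyond the scatter); an 18-fold lower number from compound 2 to compound 4 (1.26 log units; beyond the scatter)), which places the sharp divide in this short series between the two dialkylamino compounds and the two (sec-butyl)amino compounds. No measured evidence here accounts for that divide.

Still open, on these data alone, is whether dimethylamino or a cyclic amine such as piperidine or morpholine at this position stays level with compound 1 and compound 4. Also open, as far as these compounds go, is whether an unbranched monoalkylamino group such as n-butylamino behaves like (sec-butyl)amino.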